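Ring methyl on the compound 3 scaffold

The compounds below may be only part of what the source reports. "The series", "measured", "known", "first", "only" and "open" are said of these compounds alone.

Measured in a functional assay on the whole organism for antagonist activity, with Mus musculus as the target; a lower number here means that less compound is needed, a higher number that more compound is needed for the effect:
- compound 1 `CC(=O)N(C)C(C)C#CCn1cncc1C`: 1.1 mg/kg
- compound 2 `CC(=O)NCC#CCn1cncc1C`: 66 mg/kg
- compound 3 `CC(=O)N(C)CC#CCn1ccnc1`: > 100 mg/kg

Compound 3 has no numerical value in this assay, only the limit > 100 mg/kg. On these data alone, its true position therefore stays open on one side, and any step starting from it is uncertain in size.

Compound 4 `CC(=O)N(C)CC#CCn1cncc1C` differs from compound 3 by a single change, methyl in place of hydrogen on an aromatic carbon. Going by the values given here, no measured pair isolates this change, so the expectation rests on indirect evidence. Compound 1 carries the same ring methyl and gives 1.1 mg/kg. Compound 2 also carries it and gives 66 mg/kg. Both give numbers, and their values lie far apart, so the methyl alone does not fix the dose.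

A clear move towards a lower dose is expected, beyond the usual scatter, with the estimated change being an at least 6.6-fold lower number from compound 3 to compound 4 (0.82 log units; beyond the scatter). For compound 4 the estimated value is 15 mg/kg, with an expected range from 3 mg/kg to 80 mg/kg.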

Compound 4, dose for half-maximal effect: 6.6 mg/kg
Compound 4: the middle estimate sits 2.3-fold (0.36 log units) above what was measured, within the range that was stated.
By their numbers in this assay, from the lowest: compound 1; then compound 4; then compound 2. At a limit, above all of these: compound 3.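

In this assay the ring methyl now stands alone in a single pair, with an at least 15-fold lower number from compound 3 to compound 4 (1.18 log units; beyond the scatter), which makes this aromatic carbon a position where one added methyl is enough to bring the compound from no numerical value to a measurable dose. Compound 3 gives only a limit and not a number, so this step has an open end and its true size may be larger: the limit of > 100 mg/kg in this assay, at which 1 of the 4 values shown sits.

With the ring methyl in place, the two other methyl positions still move the dose: methyl on the amide-type nitrogen gives a 10-fold lower number from compound 2 to compound 4 (1.00 log units; beyond the scatter), and hydrogen in place of methyl on the saturated chain carbon gives a 6.0-fold higher number from compound 1 to compound 4 (0.78 log units; beyond the scatter), so the ring methyl is not the only methyl in this series that matters.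

On these data alone, it remains open whether a different group on this ring carbon, such as ethyl or a chlorine atom, would lower the dose further or raise it. Also open, as far as these compounds go, is whether the ring methyl would give a step of similar size on the cores of compound 1 and compound 2.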